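This account rests on a few compounds, and the source may have more. Where it says the series, first, only, none or still open, it means among the compounds named here.

Two compounds share the same core, an aromatic ring carrying an acetyl group and a phenol. Compound 1 `CCc1cc(C(C)=O)c(O)cc1OCCCC(C)(C)C(=O)O`, which bears an ethyl group and an ether chain ending in a carboxylic acid, gives 89% in an assay on isolated protein for inhibition of leukotriene B4 receptor 1 (Homo sapiens), tested at 10 uM; a lower number here means less inhibition, a higher number more inhibition at the concentration tested (going by the name of the read-out). Compound 2 `C=CCc1cc(C(C)=O)c(O)cc1OCc1ccc(C#N)cc1`, which carries an allyl group and an ether bearing a benzyl group with a nitrile, gives 22% in this assay; this is the lower of the two values, and the gap to compound 1 lies beyond the usual scatter. Compound 3 `CCc1cc(C(C)=O)c(O)cc1OCc1ccc(C#N)cc1` has not been measured. It differs from compound 2 in one place: methyl in place of vinyl on a saturated chain carbon bound to an aromatic carbon. Among the measured compounds shown here, no measured pair shows this change on its own, so its effect is unknown here; a step within the scatter, in either direction, is expected. Compound 3 is therefore expected to give about 28% in this assay, with a plausible range from 10% to 50%, a step of a number 6 percentage points higher from compound 2 to compound 3 (within the scatter).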

Compound 3, a percentage reported as inhibition, at one concentration (the size of the read-out at that concentration, not a potency): 7%
Beside the measured number, compound 3's estimate is 21 percentage points above it; measured number below the stated range.
By their numbers in this assay, from the lowest: compound 3; then compound 2; then compound 1.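

In this assay the swap of allyl for ethyl, on a saturated chain carbon bound to an aromatic carbon, reads as a number 15 percentage points lower from compound 2 to compound 3 (beyond the scatter) and so is not a silent change. The earlier compounds shown here differ in more than one place and could not isolate this position, whereas here the benzyl ether bearing the nitrile stays the same and only the vinyl gives way to a methyl. Nothing available here accounts for this drop in inhibition.

Going by these compounds, whether allyl to ethyl does the same with the ether chain ending in a carboxylic acid stays open. So does what a propyl chain or an amine at this position would give, and with it whether inhibition follows the length of the chain at all.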